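Trifluoromethyl to methyl on the aniline series

This account rests on a few compounds, and the source may have more. Where it says the series, first, only, none or still open, it means among the compounds named here.

For the measured compounds named here, in a functional assay on MCF7 cells (Breast, Homo sapiens) for inhibition (a higher number here means a weaker inhibitor of growth, a lower number a stronger inhibitor of growth), compound 3 `Nc1ccc(-c2nc3ccccc3s2)cc1C(F)(F)F` gives 1500 nM, the only true number so far. Compound 4 `Cc1cc(-c2nc3ccccc3s2)ccc1N` differs from compound 3 as follows: methyl in place of trifluoromethyl on an aromatic carbon. This places methyl in place of trifluoromethyl on an aromatic carbon, ortho to an amino group. Compound 1 `Cc1cc(-c2nc3c(F)cccc3s2)ccc1N` carries that methyl and reads < 10 nM, which is a limit of the assay. Compound 2 `Cc1cc(-c2nc3cccc(F)c3s2)ccc1N` also carries it and reads < 10 nM, again a limit. On those two readings, a large step toward stronger growth inhibition is expected, with a 250-fold lower number from compound 3 to compound 4 (2.40 log units; beyond the scatter) as the estimated size. For compound 4 the estimated value in this assay is 6 nM, with an expected range of 1 nM to 40 nM.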

Compound 4, concentration for 50% growth inhibition: < 10 nM
Compound 4: only a limit was reported; the forecaster's own chance of this, stated with the estimate: 65%; the middle value is on the limit's open side.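

In this assay, for the compounds shown here, methyl in place of trifluoromethyl on the aromatic carbon ortho to an amino group gives an at least 150-fold lower number from compound 3 to compound 4 (2.17 log units; beyond the scatter), the first step that can be read for this position. The earlier methyl compounds, compound 1 and compound 2, both carried a fluoro, whereas compound 4 shows that the reading reaches the same limit without one. That reading for compound 4 is a limit, so the step gives only a minimum size.

From the compounds shown here alone, the steps from compound 1 and compound 2 to compound 4 cannot be read, so any effect of the fluoro remains open: the limit of < 10 nM in this assay, at which 3 of the 4 values shown sit. Whether chloro, ethyl or methoxy at this carbon would keep the reading at that limit also remains open.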